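Side-chain swap at the amide-bearing carbon

The source may report more compounds than this note shows. Statements on the series, on what has been measured and on what is new or still open speak of the compounds shown alone.

Compound 1 `CC(C)[C@H](NC(=O)CN(c1nc(Cl)nc2[nH]cnc12)C1CC1)C(=O)OCc1ccccc1` stands as the higher of the two numbers in a functional assay on the whole organism (Tail, strain ICR) with Mus musculus as the target, in the tail flick test, with a stated time of 90 min, at a dose of 25 umol/kg by the oral route (a lower number here means a weaker effect, a higher number a stronger effect of the compound at the dose given), where compound 1 gives 51.3%. For the measured compounds named here, compound 2 `CC(C)[C@H](NC(=O)CN(c1nc(Cl)nc2[nH]cnc12)C1CC1)C(=O)O` gives 30.3% in this assay, and the single measured step, a number 21 percentage points lower from compound 1 to compound 2 (beyond the scatter), touches a different place from the change considered here. Compound 3 `CSCC[C@H](NC(=O)CN(c1nc(Cl)nc2[nH]cnc12)C1CC1)C(=O)OCc1ccccc1` differs from compound 1 by 2-(methylsulfanyl)ethyl in place of isopropyl on a saturated chain carbon bound to an amide-type nitrogen and a carbonyl carbon. Going by the values given here, no measured step bears on this change, so the step of a number 3.3 percentage points lower from compound 1 to compound 3 (within the scatter) is expected to stay within the scatter. Compound 3 is therefore estimated at 48%, with a range from 30% to 65%.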

Compound 3, a percentage reported as activity, at one dose (the size of the read-out at that dose, not a potency): 44.6%
Beside the measured number, compound 3's estimate is 3.4 percentage points above it; the range from low to high includes it.
By their numbers in this assay, from the lowest: compound 2; then compounds 3 and 1 (each within the scatter of the next).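

In this assay, the swap of isopropyl for 2-(methylsulfanyl)ethyl on the saturated chain carbon bound to an amide-type nitrogen and a carbonyl carbon gives a number 6.7 percentage points lower from compound 1 to compound 3 (within the scatter). For the compounds shown here, this is the first reading at this place, and it shows that the sulfur-bearing chain is tolerated here while the benzyl group on the oxygen is kept. No available evidence bears on why the two chains read alike.

Still open, from the compounds shown here alone, is whether a chain carrying an amine or a phenyl ring would hold the read-out at this place. Also open, going by these compounds, is how 2-(methylsulfanyl)ethyl behaves when paired with the free carboxylic acid.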